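Ethyl ester biaryls: ethoxy to hydroxy on the outer ring

The compounds below may be only part of what the source reports. "The series", "measured", "known", "first", "only" and "open" are said of these compounds alone.

Measured so far:
- compound 1, `CCOC(=O)c1cc(-c2ccc(OCC)cc2)ccn1`: 105000 nM
- compound 2, `CCOC(=O)c1cccc(-c2ccc(OCC)cc2)c1`: 50000 nM

Both compounds were tested in an assay on COS-7 cells for inhibition of patatin-like phospholipase domain-containing protein 2 (Mus musculus); a higher number here means a weaker inhibitor, a lower number a stronger inhibitor. Compound 2 gives 50000 nM and holds the lowest number of the two; its nearest neighbour, compound 1, gives 105000 nM, and the gap between them lies beyond the scatter. Going by the values given here, no pair differing in a single place has been measured, so no step size has been established.

Compound 3, `CCOC(=O)c1cccc(-c2ccc(O)cc2)c1`, has not yet been measured. Relative to compound 2 the change is hydrogen in place of ethyl on an oxygen on an aromatic ring. Among the compounds with values here, with no measured step to draw on, the direction is open; a modest loss or a change within the scatter seems the most likely outcome, and both compounds sit in a weak range where a limit rather than a number may be reported.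

For compound 3 the estimate in this assay is 80000 nM, range 25000 nM to 250000 nM. The expected step of a 1.6-fold higher number from compound 2 to compound 3 (0.20 log units; within the scatter) is small and toward a weaker result.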

Compound 3, half-maximal inhibitory concentration: 100000 nM
Estimate against measurement, compound 3: 1.3-fold (0.10 log units) below; measured number inside the range.
By their numbers in this assay, from the lowest: compounds 2, 3 and 1 (each within the scatter of the next, the first and the last beyond it).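

In this assay, going by these compounds alone, compound 2 and compound 3 form the first pair that differs in one place, so the series now has a measured step: a 2.0-fold higher number from compound 2 to compound 3 (0.30 log units; within the scatter). Hydrogen in place of ethyl on this oxygen therefore gives no change that can be told apart from the scatter, and this pair does not show that the ethyl is needed for the activity seen with compound 2, though a single pair cannot exclude a small real effect. Nothing measured here bears on the reason for this result.

From the compounds shown here alone, whether a longer chain such as butyl on the same oxygen, or an amine in place of that oxygen, would move the number beyond the scatter remains open. Also open, going by these compounds, are whether the same ethoxy to hydroxy change on the core of compound 1 would give a similar step, and whether a carboxylic acid in place of the ethyl ester would change the number in this weak range.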